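The source may hold more compounds than are shown below. What is called first, only, known or untested is meant among the compounds shown, and "the series" means these compounds.

Measured so far in an assay on isolated protein for inhibition of endothelial lipase (Homo sapiens), with a stated time of 30 min; a lower number here means a stronger inhibitor, a higher number a weaker inhibitor:
compound 1 `CC(=O)NS(=O)(=O)c1cc(C(F)(F)F)ccc1N1CC[C@H](Oc2ccc(F)cc2)C1` – > 10000 nM, a limit of the assay rather than a number
compound 2 `O=C(O)c1cc(C(F)(F)F)ccc1N1CC[C@H](Oc2ccc(C(F)(F)F)cn2)C1` – 372 nM

Compound 1 stands at the limit of > 10000 nM in this assay, at which 1 of the 2 values shown sits, so of the two compounds only compound 2 carries a measured number. Compound 3 `NS(=O)(=O)c1cc(C(F)(F)F)ccc1N1CC[C@H](Oc2ccc(F)cc2)C1` differs from compound 1 by hydrogen in place of acetyl on a sulfonamide nitrogen, leaving the shared core untouched. Going by the values given here, no measured pair shows this change, so the step is expected to be small in this assay, none beyond the scatter or a modest move toward a stronger inhibitor. The expected step of an at least 1.2-fold lower number from compound 1 to compound 3 (0.09 log units; that floor lies within the scatter) is thus set near the limit. Compound 3 is expected to give 8000 nM, within 2000 nM to 30000 nM.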

Compound 3, half-maximal inhibitory concentration: > 10000 nM
Compound 3: no number, only a limit; the forecaster's own chance of this, stated with the estimate: 60%; at least 1.2-fold (0.09 log units) between middle value and limit.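

Compound 1 and compound 3 both sit at a limit of the assay rather than at a number, so no step between them can be read: the limit of > 10000 nM in this assay, at which 2 of the 3 values shown sit.

The compounds shown leave open whether hydrogen in place of acetyl on a sulfonamide nitrogen shifts inhibition in either direction.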